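This account rests on a few compounds, and the source may have more. Where it says the series, first, only, none or still open, it means among the compounds named here.

In a functional assay on MCF7 cells (Homo sapiens) for antiproliferative activity, read by MTT assay (on this read-out higher numbers stand for weaker inhibition and lower numbers for stronger inhibition), compound 1 (`CC/C=C\C/C=C\C/C=C\CCCCCCCc1cc(=O)c2c(O)cc(OCOC)cc2o1`) gives 17500 nM and stands level with compound 2 (`CC/C=C\C/C=C\C/C=C\CCCCCCCc1cc(=O)c2c(O)c(C)c(OCOC)cc2o1`) at 17500 nM on this scale. Compound 3 (`CCCCC/C=C\C/C=C\CCCCCCCc1cc(=O)c2c(O)cc(OCOC)cc2o1`) differs from compound 1 only in the chain (butyl in place of but-1-en-1-yl on a saturated chain carbon bound to a double-bonded chain carbon): butyl in place of but-1-en-1-yl on a saturated chain carbon bound to a double-bonded chain carbon. For the measured compounds named here, no measured step touches that chain. The only one, no change at the digits printed from compound 1 to compound 2 (within the scatter) for methyl in place of hydrogen on an aromatic carbon, stayed within the scatter and offers only weak guidance. In this assay the expected step, no change at the digits printed from compound 1 to compound 3 (within the scatter) by estimate, is none beyond the scatter. Compound 3 is estimated at 17500 nM (expected range 8000 nM to 38000 nM).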

Compound 3, half-maximal inhibitory concentration: > 67200 nM
Compound 3: a limit, no number; the forecaster's own chance of this, stated with the estimate: 10%; at least 3.8-fold (0.58 log units) between middle value and limit.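

In this assay, the chain end matters in a way that methyl on an aromatic carbon in compound 2 did not show: butyl in place of but-1-en-1-yl gives an at least 3.8-fold higher number from compound 1 to compound 3 (0.58 log units; beyond the scatter). Losing the double bond of but-1-en-1-yl at this place on the chain is therefore enough to weaken inhibition beyond the scatter. As far as these compounds go, compound 3 stands at > 67200 nM, which is a limit of the assay and not a number, so the full size of the step stays unknown. From the compounds shown here alone, whether a longer chain or a fully saturated chain would weaken inhibition further stays open.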